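The source may report more compounds than this note shows. Statements on the series, on what has been measured and on what is new or still open speak of the compounds shown alone.

Measured compounds in a functional assay on HL-60 cells (Homo sapiens) for antiproliferative activity, read by MTT assay, with a stated time of 48 h; on this read-out lower numbers stand for stronger inhibition and higher numbers for weaker inhibition:

compound 1 `C=CC(=O)Nc1ccc(-c2nc(Cl)cc(Nc3ccc(C(=O)N(CC)CC)cc3)n2)cc1`: 9340 nM
compound 2 `C=CC(=O)Nc1ccc(-c2nc(Cl)cc(Nc3ccc(C(=O)Nc4ccc(OC)cc4)cc3)n2)cc1`: "not determined" (no result reported)
compound 3 `C=CC(=O)Nc1ccc(-c2nc(Cl)cc(Nc3ccc(C(=O)N4CCCC4)cc3)n2)cc1`: 15800 nM

All three share the same core and differ only in the group on the carbonyl carbon attached to the aromatic ring. Compound 2, with an anilide there, has no number in this assay and gives no guidance. Compound 3 stands with compound 1: the one step that connects them, a 1.7-fold higher number from compound 1 to compound 3 (0.23 log units; within the scatter), lies within the scatter, so the two are not told apart on the numbers shown.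

Compound 4 `C=CC(=O)Nc1ccc(-c2nc(Cl)cc(Nc3ccc(C(=O)N(C)C)cc3)n2)cc1` is not yet measured. It differs from compound 3 by dimethylamino in place of pyrrolidin-1-yl on a carbonyl carbon. Among the measured compounds shown here, the only step that bears on this change is the exchange of one amide substituent for another at the same carbonyl carbon, a 1.7-fold higher number from compound 1 to compound 3 (0.23 log units; within the scatter), which stayed within the scatter. Two open-chain dialkylamino groups and one ring amine have therefore given numbers of the same size, and nothing in the series points to a change beyond the scatter in this assay for a smaller dialkylamino group.

Compound 4 is expected at 12000 nM, with a range of 5000 nM to 30000 nM, the expected step of a 1.3-fold lower number from compound 3 to compound 4 (0.12 log units; within the scatter) being within the scatter.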

Compound 4, half-maximal inhibitory concentration: > 50000 nM
Compound 4: no number, only a limit; the forecaster's own chance of this, stated with the estimate: 10%; middle value at least 4.1-fold (0.61 log units) away from the limit.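

In this assay, the two new steps are an at least 3.1-fold higher number from compound 3 to compound 4 (0.50 log units; beyond the scatter) and an at least 5.3-fold higher number from compound 1 to compound 4 (0.72 log units; beyond the scatter), and both lie beyond the scatter, whereas the earlier exchange of diethylamino for pyrrolidin-1-yl, a 1.7-fold higher number from compound 1 to compound 3 (0.23 log units; within the scatter), stayed within it. The group on this carbonyl carbon can therefore shift the read-out, and among the three groups with a reading here, dimethylamino is the one that separates from the other two, while diethylamino and pyrrolidin-1-yl remain indistinguishable. The result for compound 4 is a limit and not a number: the limit of > 50000 nM in this assay, at which 1 of the 4 values shown sits.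

The compounds shown leave open where between dimethylamino and diethylamino the change sets in, which an ethyl(methyl)amino group would address, and whether ring amines such as piperidin-1-yl or morpholin-4-yl stay level with pyrrolidin-1-yl. Also open, as far as these compounds go, are the full size of both steps to compound 4 and how a secondary amide such as the anilide of compound 2, which has no reported result, compares with these tertiary amides.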